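Nitro in place of chloro on a shared core

The source may report more compounds than this note shows. Statements on the series, on what has been measured and on what is new or still open speak of the compounds shown alone.

Of the compounds shown here, three built on the same core have been tested for cytotoxicity toward human fibroblast cells. Compound 1 `COc1cc(O)c(C(=O)/C=C/c2ccc(F)cc2)c(OC)c1` was measured in an ADME assay on cells (Fibroblast, Homo sapiens) for cytotoxicity, with a stated time of 48 h (a higher number here means a weaker inhibitor, a lower number a stronger inhibitor), and gives > 20000 nM, which is a limit of the assay rather than a number. Compound 2 `COc1cc(OC)c(C(=O)/C=C/c2ccc(Cl)cc2)c(OC)c1` gives > 20000 nM in this assay, again a limit and not a number. Compound 3 `COc1cccc(/C=C/C(=O)c2c(O)cc(OC)cc2OC)c1` gives > 20000 nM in this assay, also only a limit. Compound 2 therefore stands at the limit of > 20000 nM in this assay, at which 3 of the 3 values shown sit, so nothing separates it from the other two compounds on the numbers shown.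

The unmeasured compound 4 `COc1cc(OC)c(C(=O)/C=C/c2ccc([N+](=O)[O-])cc2)c(OC)c1` is related to compound 2 by one change: nitro in place of chloro on an aromatic carbon. The change sits para to a large group on the aromatic ring.

Within the data shown here, since every measured compound sits at the same limit, no step between measured compounds can be read off, and there is no basis for expecting the nitro for chloro exchange to move the result beyond the scatter of this assay in either direction. Compound 4 is therefore expected to sit at 25000 nM, in a range from 8000 nM to 60000 nM. The expected step that the limit leaves unreadable from compound 2 to compound 4 is thus essentially none, with a high chance that compound 4 again shows only a limit.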

Compound 4, half-maximal inhibitory concentration: 7300 nM
Beside the measured number, compound 4's estimate is 3.4-fold (0.53 log units) above it; the whole stated range lies above it.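

This position on the aromatic ring is not silent in this assay: nitro in place of chloro gives an at least 2.7-fold lower number from compound 2 to compound 4 (0.43 log units; beyond the scatter), so a single exchange, para to a large group, moves the result by more than the usual scatter, toward stronger inhibition of fibroblast growth or survival. Among these compounds, compound 4 is the first compound here to give a real number, and the earlier compounds, all at a limit, offered no step that could be read, so they could not show that this series can register any effect at all in this test. The true size of the step stays unknown, since the starting point is only a limit, and compound 4 stands alone in leaving it: the limit of > 20000 nM in this assay, at which 3 of the 4 values shown sit.

On these data alone, what remains open is whether the change in the number belongs to nitro in particular, or whether an amine or a carboxylic acid on the same aromatic carbon would also bring the number down. Also unsettled is whether nitro would have the same effect on the core of compound 1, and the data give no reason for the step.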